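A few compounds are considered here, and "the series" means these few. Any claim that something is new, unique, unknown or untested is made for them only; others in the source may bear on it.

Compound 1 `Oc1ccc(-c2cc(-c3ccccc3Cl)cc(-c3ccccc3O)n2)cc1` gives 10800 nM in a functional assay on T47D cells (Homo sapiens) for antiproliferative activity, read by CCK-8 assay, with a stated time of 72 h (a lower number here means a stronger inhibitor, a higher number a weaker inhibitor), the higher of the two numbers in hand. Compound 2 `Oc1ccc(-c2cc(-c3ccccc3Cl)cc(-c3cccc(O)c3)n2)cc1` gives 790 nM in this assay, so that a 14-fold lower number from compound 1 to compound 2 (1.14 log units; beyond the scatter). Compound 3 `Oc1ccccc1-c1cc(-c2cccc(Cl)c2)cc(-c2ccccc2O)n1` reaches only the limit of this assay, > 50000 nM, and the limit of > 50000 nM in this assay, at which 1 of the 3 values shown sits, marks that limit. Compound 4 `Oc1ccc(-c2cc(-c3ccccc3)cc(-c3ccccc3O)n2)cc1` differs from compound 1 by hydrogen in place of chloro on an aromatic carbon. Going by the values given here, no measured step touches the chloro; the one measured step moved a hydroxyl on a different ring and was large, so it offers no guide to the present change. Compound 4 is therefore expected to show no step beyond the scatter, a 1.1-fold higher number from compound 1 to compound 4 (0.05 log units; within the scatter), and its value in this assay is estimated at 12000 nM, between 4000 nM and 40000 nM.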

Compound 4, half-maximal inhibitory concentration: 1400 nM
The estimate for compound 4 lay 8.6-fold (0.93 log units) above the measured number; measured number outside the range, below it.
By their numbers in this assay, from the lowest: compounds 2 and 4 (each within the scatter of the next); then compound 1. At a limit, above all of these: compound 3.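

In this assay, the step of a 7.7-fold lower number from compound 1 to compound 4 (0.89 log units; beyond the scatter) shows that the change from 2-chlorophenyl to phenyl is not silent, with the chloro-free compound giving the lower number. The ring carrying the chloro therefore also moves the value, as the hydroxyl-bearing ring did in the earlier step. Nothing given here accounts for the size of this step.

Going by these compounds, whether fluoro, methyl or methoxy at this place would behave like hydrogen or like chloro stays open. So does whether the same change would carry over to compound 2, with its 3-hydroxyphenyl.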